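Swapping the bicyclic ether group on an anilinoquinazoline core

This account rests on a few compounds, and the source may have more. Where it says the series, first, only, none or still open, it means among the compounds named here.

Measured so far:
compound 1 `Cc1cc(Nc2ncnc3cc(O)c(NC(=O)/C=C/[C@H]4CCCN4C)cc23)ccc1Oc1ccn2ccnc2c1` — 4.55 nM
compound 2 `Cc1cc(Nc2ncnc3cc(O)c(NC(=O)/C=C/[C@H]4CCCN4C)cc23)ccc1Oc1ccn2ncnc2c1` — 2.65 nM
compound 3 `Cc1cc(Nc2ncnc3cc(O)c(NC(=O)/C=C/[C@H]4CCCN4C)cc23)ccc1Oc1ccn2cnnc2c1` — 32.9 nM

All three share one core and differ only in the bicyclic group attached through an oxygen on an aromatic ring. In a functional assay on NCI-N87 cells (Homo sapiens) for inhibition, read by CellTiter-Glo, with a stated time of 72 h (a higher number here means a weaker inhibitor, a lower number a stronger inhibitor), compound 1 gives 4.55 nM, the second highest of the three numbers; compound 2 sits nearest, with a 1.7-fold lower number from compound 1 to compound 2 (0.23 log units; within the scatter), while compound 3 lies furthest, with a 7.2-fold higher number from compound 1 to compound 3 (0.86 log units; beyond the scatter).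

Compound 4 `Cc1cc(Nc2ncnc3cc(O)c(NC(=O)/C=C/[C@H]4CCCN4C)cc23)ccc1Oc1cc2nccn2cn1` has not yet been measured. It differs from compound 1 at the same position as the other two:

a group of 9 heavy atoms (6 carbon, 3 nitrogen; one five-membered aromatic ring with 2 hetero atoms, one six-membered aromatic ring with 2 hetero atoms) in place of a group of 9 heavy atoms (7 carbon, 2 nitrogen; one five-membered aromatic ring with 2 hetero atoms, one six-membered aromatic ring with 1 hetero atom), on an oxygen on an aromatic ring

The steps from compound 1 to compound 2 and to compound 3 both exchange this group for one carrying an extra nitrogen, and they point in different directions: one within the scatter, one a modest loss. Within the data shown here, no measured step places the extra nitrogen in the six-membered ring, so the expectation for compound 4 is broad. A small loss is expected, a 1.5-fold higher number from compound 1 to compound 4 (0.19 log units; within the scatter), on the grounds that one of the two comparable changes, a 7.2-fold higher number from compound 1 to compound 3 (0.86 log units; beyond the scatter), weakened inhibition. Compound 4 is estimated at 7 nM, with a range from 2.5 nM to 25 nM.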

Compound 4, half-maximal inhibitory concentration: 41.7 nM
Beside the measured number, compound 4's estimate is 6.0-fold (0.78 log units) below it; measured number above the stated range.
By their numbers in this assay, from the lowest: compounds 2 and 1 (each within the scatter of the next); then compounds 3 and 4 (each within the scatter of the next).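

Moving the extra nitrogen into the six-membered ring gives a 9.2-fold higher number from compound 1 to compound 4 (0.96 log units; beyond the scatter) in this assay, so this placement, like that in compound 3, weakens inhibition. Atom counts alone do not settle the outcome at this position: compounds 2 and 4 carry groups with the same 6 carbon and 3 nitrogen atoms, yet the change gives a 16-fold higher number from compound 2 to compound 4 (1.20 log units; beyond the scatter) and the distribution of those nitrogens between the two rings differs. Two different rearrangements also end up close together, with a 1.3-fold higher number from compound 3 to compound 4 (0.10 log units; within the scatter) in the same assay, so the loss is not confined to a nitrogen in the five-membered ring.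

Going by these compounds, it remains open whether a methyl group or an amine on the bicyclic group of compound 4 would change its number. Nothing available here explains why these nitrogen placements give different results.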